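Trimming the side chain of a cyclopropanecarboxamide agonist

The compounds below may be only part of what the source reports. "The series", "measured", "known", "first", "only" and "open" are said of these compounds alone.

The three compounds share one skeleton: a cyclopropane bearing a phenyl ring, joined through an amide to a biphenyl-bearing nitrogen, which in turn carries a short saturated chain ending in a primary amine. They differ only in that chain. Compound 2, `CO[C@H](C)[C@H](N)CN(C(=O)[C@@H]1C[C@H]1c1ccccc1)c1ccc(-c2ccccc2)cc1`, is the reference point. Within the data shown here, in a functional assay for agonist activity at G protein-coupled receptor 88 (Homo sapiens), read by HTRF and cAMP accumulation (on this read-out higher numbers stand for an effect only at larger amounts of compound and lower numbers for an effect already at smaller amounts), compound 2 gives 0.68 nM, the only number recorded for it. Compound 1, `CC[C@H](C)[C@H](N)CN(C(=O)[C@@H]1C[C@H]1c1ccccc1)c1ccc(-c2ccccc2)cc1`, differs from compound 2 in the same chain and is measured twice in this assay; compound 1 gives 230 nM; 800 nM (2 entries), the two entries being (the several entries of compound 1 in this assay, 230 nM; 800 nM (2 entries)).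

Compound 3, `CC(C)(N)CN(C(=O)[C@@H]1C[C@H]1c1ccccc1)c1ccc(-c2ccccc2)cc1`, carries the change (1-amino-1-methylethyl in place of 1-amino-2-methoxypropyl on a saturated chain carbon bound to an amide-type nitrogen). Among the measured compounds shown here, no step between two measured compounds matches this change, so the expectation rests on the two values shown. The step from compound 2 to compound 3 is expected to be a loss, a 290-fold higher number from compound 2 to compound 3 (2.47 log units; beyond the scatter), beyond the usual scatter. Compound 3 is therefore estimated at 200 nM, within a range from 20 nM to 2000 nM.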

Compound 3, half-maximal effective concentration: 1.4 nM
Compound 3: middle estimate off by 140-fold (2.15 log units), on the high side; the measured number lies below the stated range.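

In this assay this change costs little: the result is a 2.1-fold higher number from compound 2 to compound 3 (0.31 log units; beyond the scatter), a modest step, though one beyond the usual scatter. At this place, on a saturated chain carbon bound to an amide-type nitrogen, a number this low therefore does not depend on keeping the methoxy oxygen or the 2 defined stereocentres of 1-amino-2-methoxypropyl, since the smaller 1-amino-1-methylethyl group, which has neither, stays close behind. Compound 1 also has no oxygen in its chain, yet its numbers are far higher than those of compound 3, so the absence of that oxygen cannot by itself account for them, and its own entries lie well apart: the several entries of compound 1 in this assay, 230 nM; 800 nM (2 entries).

What sets compound 1 apart from compound 3 remains unexplained, since the compounds shown offer no series that changes the chain one atom at a time. On these data alone, it also remains open whether a hydroxyl in place of the methoxy, or a cyclopropane ring bearing the amine in place of the 1-amino-1-methylethyl group, would keep the number this low.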